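Removing the bromo from compound 1: expected tolerance in cytotoxicity

The source may report more compounds than this note shows. Statements on the series, on what has been measured and on what is new or still open speak of the compounds shown alone.

The series shares one core carrying two aryl groups, one of which varies in its substituent. Going by the values given here, compound 1 `FC(F)(F)c1ccc(NCc2cn(-c3ccccc3)nc2-c2ccc(Br)cc2)cc1` is the only member with a definite number in an ADME assay on BHK-21 cells (Mesocricetus auratus) for cytotoxicity, read by MTT assay, with a stated time of 72 h; a higher number here means that more compound is tolerated, a lower number that less compound is tolerated; compound 1 gives 20000 nM. Compound 2 `Clc1ccc(NCc2cn(-c3ccccc3)nc2-c2ccc(Br)cc2)cc1` gives in this assay only a limit of the assay, with both of its entries reading > 100000 nM; > 100000 nM (2 entries). Compound 3 `Cc1ccc(NCc2cn(-c3ccccc3)nc2-c2ccc(Br)cc2)cc1` likewise gives in this assay a limit of the assay, > 100000 nM. Among the compounds with values here, the single step that can be sized is an at least 5.0-fold higher number from compound 1 to compound 3 (0.69 log units; beyond the scatter), and it rests on the limit (the limit of > 100000 nM in this assay, at which 1 of the 3 values shown sits).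

Compound 4 `FC(F)(F)c1ccc(NCc2cn(-c3ccccc3)nc2-c2ccccc2)cc1` differs from compound 1 by hydrogen in place of bromo on an aromatic carbon. Within the data shown here, no measured step touches this group: the sized step from compound 1 to compound 3 concerns the trifluoromethyl, not the bromo. With nothing bearing on the change, no step beyond the scatter is expected in this assay, though the assay may report only a limit. Compound 4 is expected to give 30000 nM, between 10000 nM and 100000 nM. The estimated step of a 1.5-fold higher number from compound 1 to compound 4 (0.18 log units; within the scatter) is expected to stay within the scatter.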

Compound 4, half-maximal cytotoxic concentration: 37000 nM
Beside the measured number, compound 4's estimate is 1.2-fold (0.09 log units) below it, within the range that was stated.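

Replacing 4-bromophenyl with phenyl gives in this assay a 1.9-fold higher number from compound 1 to compound 4 (0.27 log units; within the scatter), so within this pair the bromo has no effect that can be told from the scatter. Both ends of this step are definite numbers, so, unlike the earlier sized step, it does not rest on the ceiling of the assay: the limit of > 100000 nM in this assay, at which 1 of the 4 values shown sits. The two trifluoromethyl compounds shown, compound 1 and compound 4, both give definite numbers, with or without the bromo.

Whether the bromo is equally dispensable alongside the chloro of compound 2 or the methyl of compound 3 remains open, as neither has a partner with phenyl among the compounds shown. Also open, going by these compounds, is how an amine or a carboxylic acid in place of the bromo would read in this assay.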